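Dropping a Methyl from the Sulfonyl Ring

The compounds below may be only part of what the source reports. "The series", "measured", "known", "first", "only" and "open" are said of these compounds alone.

Measured compounds:
- compound 1, `COc1cc(C(=O)NS(=O)(=O)c2ccccc2Cl)ccc1Cc1nn(C)c2ccc(NC(=O)OC3CCCC3)cc12`: 1 mg/kg
- compound 2, `CCCn1cc(Cc2ccc(C(=O)NS(=O)(=O)c3ccccc3)cc2OC)c2cc(NC(=O)OC3CCCC3)ccc21`: 1 mg/kg
- compound 3, `COc1cc(C(=O)NS(=O)(=O)c2ccccc2C)ccc1Cc1cn(C)c2ccc(NC(=O)CC3CCCC3)cc12`: 0.2 mg/kg

In a functional assay on the whole organism with Cavia porcellus as the target (a higher number here means that more compound is needed for the effect, a lower number that less compound is needed), compound 3 needs the smallest dose of the three. Its distance from compound 1 and from compound 2 is the same, and both distances lie beyond the usual scatter, so compound 3 can be called the most potent compound measured here.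

Compound 4, `COc1cc(C(=O)NS(=O)(=O)c2ccccc2)ccc1Cc1cn(C)c2ccc(NC(=O)CC3CCCC3)cc12`, has not yet been measured. It differs from compound 3 in one place: hydrogen in place of methyl on an aromatic carbon. The methyl sits ortho to a large group, and only a single carbon leaves.

For the measured compounds named here, no measured pair shows a change of this kind, so there is nothing to copy from. A single carbon lost from an aromatic ring is a small change, and the expectation is a step in this assay of no size beyond the scatter, with no confident direction. Compound 4 is therefore estimated at 0.3 mg/kg, within a range from 0.1 mg/kg to 1 mg/kg. This estimate means a step from compound 3 to compound 4 of a 1.5-fold higher number from compound 3 to compound 4 (0.18 log units; within the scatter).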

Compound 4, dose for half-maximal effect: 1 mg/kg
Compound 4: middle estimate off by 3.3-fold (0.52 log units), on the low side; low and high end bracket the measured number.
By their numbers in this assay, from the lowest: compound 3; then compounds 1, 2 and 4 (each within the scatter of the next).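

For the compounds shown here, compound 3 and compound 4 form the first pair here that differs in only one place, so the effect of this methyl can be read directly. In this assay, the change from 2-methylphenyl to phenyl gives a 5.0-fold higher number from compound 3 to compound 4 (0.70 log units; beyond the scatter), showing that a single carbon on this aromatic ring is enough to shift the dose needed, with the smaller dose going to the compound that keeps the methyl. Nothing available here explains why this step occurs.

Compound 1 carries a chlorine on this ring but also differs elsewhere, so it cannot show how that group compares with methyl. As far as these compounds go, whether ethyl or fluorine in the same place would keep the smaller dose remains open, as does whether the methyl has the same effect in other compounds.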